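Butyl addition on two fused cores, whole-organism inhibition

This account rests on a few compounds, and the source may have more. Where it says the series, first, only, none or still open, it means among the compounds named here.

Values so far in a functional assay for inhibition, with Rattus norvegicus as the target; on this read-out higher numbers stand for weaker inhibition and lower numbers for stronger inhibition:
compound 1, `CCc1c(CC)c(OC(C)=O)c2ccccc2c1OC`: 400 nM
compound 2, `CCCCc1cccc2c(OC)c(CC)c(CC)c(OC(C)=O)c12`: 14100 nM
compound 3, `CCCCc1cc(OC)c2occc2c1O`: 11900 nM

The pair compound 1 and compound 2 differs in one place, (butyl in place of hydrogen on an aromatic carbon), and in this assay the step is a 35-fold higher number from compound 1 to compound 2 (1.55 log units; beyond the scatter). Compound 3 carries a different core; the difference between the two cores is not broken down here. Against compound 2, compound 3 stands within the scatter; against compound 1, compound 3 gives a markedly higher number.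

Compound 4, `CCCCc1c(CCCC)c(OC)c2occc2c1O`, has not yet been measured. It differs from compound 3 by butyl in place of hydrogen on an aromatic carbon. Within the data shown here, this is the same kind of change as the one from compound 1 to compound 2, but the surroundings of the place differ: in compound 2 the entering butyl sits ortho to a fused ring and meta to a fused ring, whereas in compound 4 it sits ortho to a butyl group, ortho to a methoxy group, meta to a fused ring, meta to a hydroxy group and para to a fused ring.

Among the measured compounds shown here, only one measured example of this change exists, on another core, so the transfer to compound 3 is uncertain. Still, compound 4 is expected to follow the direction of that step, with a 5.0-fold higher number from compound 3 to compound 4 (0.70 log units; beyond the scatter) as the expected size, because the earlier change gave a 35-fold higher number from compound 1 to compound 2 (1.55 log units; beyond the scatter). On that basis compound 4 is estimated at 60000 nM in this assay, within a range from 15000 nM to 300000 nM. Since compound 3 already gives 11900 nM in this assay, the number expected for compound 4 is a high one, and the assay may not resolve it fully.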

Compound 4, half-maximal inhibitory concentration: 1150 nM
Beside the measured number, compound 4's estimate is 52-fold (1.72 log units) above it, and the stated range ends above it.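

In this assay, butyl in place of hydrogen on an aromatic carbon gives a 10-fold lower number from compound 3 to compound 4 (1.01 log units; beyond the scatter), so the direction seen on the core of compound 1 does not carry over to the core of compound 3. Set side by side, the two steps run in opposite directions, and the gap between them is larger than the scatter of two such steps allows: the same change on two cores in this assay, a 35-fold higher number (1.55 log units; beyond the scatter) from compound 1 to compound 2 and a 10-fold lower number (1.01 log units; beyond the scatter) from compound 3 to compound 4, 360-fold (2.56 log units) apart, beyond the scatter of two such steps

With a single pair on each core, this shows that the change cannot be transferred here as a fixed step, but it does not show which difference between the pairs sets the sign: the cores differ, and in compound 4 the entering butyl sits ortho to a butyl group and ortho to a methoxy group, surroundings that compound 2 does not share.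

Open, from the compounds shown here alone, is whether a longer chain such as hexyl, or an amine, at that aromatic carbon on the core of compound 3 would also lower the number in this assay. Also open, going by these compounds, is whether the hydroxy group of compound 3 and compound 4, in place of the acetate ester carried by compound 1 and compound 2, has any part in the opposite steps.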